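The source may report more compounds than this note shows. Statements on the series, on what has been measured and on what is new or still open speak of the compounds shown alone.

In an ADME assay on the whole organism (strain Sprague-Dawley) for pharmacokinetics, with Rattus norvegicus as the target, using cassette dosing (a higher number here means faster removal of the compound, a lower number slower removal), compound 1 `O=C(C[C@]1(O)CC[C@@H](Cc2ccccc2)CC1)Nc1ccc2[nH]c(=O)oc2c1` gives 34.1 mL/min/kg. Within the data shown here, compound 2 `O=C(C[C@]1(O)CC[C@@H](Cc2ccc(OC(F)(F)F)cc2)CC1)Nc1ccc2[nH]c(=O)oc2c1` gives 21 mL/min/kg, which lies within the scatter of the value for compound 1, so compound 1 has no clear standing against the only other number available. Compound 3 `O=C(C[C@]1(O)CC[C@@H](Cc2ccc(F)c(F)c2)CC1)Nc1ccc2[nH]c(=O)oc2c1` keeps the core of compound 1 and carries a single change: 3,4-difluorophenyl in place of phenyl on a saturated chain carbon bound to a saturated ring carbon. In words, 3,4-difluorophenyl stands in place of phenyl on a saturated chain carbon bound to a saturated ring carbon. Among the measured compounds shown here, one measured step bears on this, the other change on the same phenyl: a 1.6-fold lower number from compound 1 to compound 2 (0.21 log units; within the scatter). That step stays within the scatter, and no other evidence is available, so no step beyond the scatter is expected in this assay, only a slight lean in the same direction. The estimated step is a 1.3-fold lower number from compound 1 to compound 3 (0.10 log units; within the scatter). For compound 3 the expected value is 27 mL/min/kg, with an estimated range of 15 mL/min/kg to 46 mL/min/kg.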

Compound 3, clearance: 35.7 mL/min/kg
For compound 3 the middle estimate is 1.3-fold (0.12 log units) below the measured one, within the range that was stated.
By their numbers in this assay, from the lowest: compounds 2, 1 and 3 (each within the scatter of the next).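

In this assay, 3,4-difluorophenyl is a second replacement for phenyl on a saturated chain carbon bound to a saturated ring carbon, and it gives (a 1.0-fold higher number from compound 1 to compound 3 (0.02 log units; within the scatter)). The two substituted groups also stay together (a 1.7-fold higher number from compound 2 to compound 3 (0.23 log units; within the scatter)), so neither 3,4-difluorophenyl nor 4-(trifluoromethoxy)phenyl separates from phenyl or from the other at this place in the three compounds shown. No measurement at hand accounts for this lack of separation.

The phenyl replacements shown all carry fluorine, so it remains open whether an amine or a carboxylic acid on that ring would give a step beyond the scatter in this assay. From the compounds shown here alone, it is equally open whether a longer chain in place of benzyl would move the clearance beyond the scatter of these three compounds.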